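A few compounds are considered here, and "the series" means these few. Any claim that something is new, unique, unknown or untested is made for them only; others in the source may bear on it.

Measured so far:
Compound 1, `CN1CCN(Cc2ccc(NC(=O)Nc3ccc4ncnc(Nc5ccc(F)c(Cl)c5)c4c3)cc2)CC1`, in a functional assay on A549 cells (Homo sapiens) for antiproliferative activity, read by MTT assay, with a stated time of 72 h (on this read-out higher numbers stand for weaker inhibition and lower numbers for stronger inhibition), compound 1 gives 3480 nM.
Compound 2, `C#Cc1cccc(Nc2ncnc3ccc(NC(=O)Nc4ccc(CN5CCN(C)CC5)cc4)cc23)c1`, in this assay compound 2 gives 5170 nM.

Among these two numbers compound 2 holds the higher one, though the step of a 1.5-fold higher number from compound 1 to compound 2 (0.17 log units; within the scatter) lies within the scatter, so the two are not separated. Compound 3, `CN1CCN(Cc2ccc(NC(=O)Nc3ccc4ncnc(Nc5ccc(F)c(F)c5)c4c3)cc2)CC1`, differs from compound 2 by 3,4-difluorophenyl in place of 3-ethynylphenyl on a nitrogen on an aromatic ring. Among the measured compounds shown here, the only measured step that bears on this change is the one from compound 1 to compound 2, a swap at the same nitrogen that stayed within the scatter. Compound 3 is therefore expected to show no step beyond the scatter, a 1.3-fold lower number from compound 2 to compound 3 (0.11 log units; within the scatter), with an estimate of 4000 nM and a range from 1500 nM to 11000 nM.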

Compound 3, half-maximal inhibitory concentration: > 10000 nM
Compound 3: a limit, no number (the forecaster's own chance of this, stated with the estimate: 3%); middle value at least 2.5-fold (0.39 log units) from the limit.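

Compound 3 gives a limit of the assay, not a number: the limit of > 10000 nM in this assay, at which 1 of the 3 values shown sits. On the ring carried by this nitrogen, fluoro in place of chloro on an aromatic carbon gives an at least 2.8-fold higher number from compound 1 to compound 3 (0.45 log units; beyond the scatter), the first step shown here that goes beyond the scatter. Against compound 2 the change to 3,4-difluorophenyl gives an at least 1.9-fold higher number from compound 2 to compound 3 (0.28 log units; that floor lies within the scatter), so those two are not separated. The compounds shown leave open how far compound 3 lies past its limit. They also leave open whether a methoxy or an amine on this ring would stay with compound 1 or go with compound 3.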